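The compounds below may be only part of what the source reports. "The series", "measured", "known", "first", "only" and "open" are said of these compounds alone.

The compounds share one core. Compound 1 `CC(C)(C)c1nc(-c2ccccc2F)c(C(=O)N2CCN(c3cccc(Cl)c3)CC2)o1` carries a tert-butyl group and a 2-fluorophenyl group, while compound 2 `O=C(c1oc(C(F)(F)F)nc1-c1ccc(F)cc1)N1CCN(c2cccc(Cl)c2)CC1` carries a trifluoromethyl group and a 4-fluorophenyl group. In a functional assay on HL-60 cells (Homo sapiens) for inhibition, read by MTT assay, with a stated time of 72 h (on this read-out higher numbers stand for weaker inhibition and lower numbers for stronger inhibition), compound 1 is reported only as a limit of the assay, > 1000 nM. In this assay compound 2 gives "not active" (no number reported), with no number attached, so compound 2 stands without any figure that would place it among its neighbours. Compound 3 `O=C(c1oc(C(F)(F)F)nc1-c1ccccc1F)N1CCN(c2cccc(Cl)c2)CC1` is the member still to be measured; it differs from compound 2 by 2-fluorophenyl in place of 4-fluorophenyl on an aromatic carbon. Both values shown point to weak inhibition, as the limit of > 1000 nM in this assay, at which 1 of the 2 values shown sits, shows, and the change itself brings in the same ring that compound 1 already carries, so in this assay no step beyond the scatter is expected in either direction. Compound 3 is therefore expected to remain weak, estimated at 5000 nM, within a range from 1000 nM to 50000 nM.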

Compound 3, half-maximal inhibitory concentration: "not active" (no number reported)
No number was reported for compound 3; there is nothing to compare the estimate with.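

Going by these compounds alone, compound 2 and compound 3 are both reported without a number, so no step between them can be read. The compounds shown leave open whether 4-fluorophenyl and 2-fluorophenyl differ at all in this assay, and none of them gives a figure other than a limit.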